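The source may report more compounds than this note shows. Statements on the series, on what has been measured and on what is new or still open speak of the compounds shown alone.

Working notes on the series.

Compound 1, `Fc1ccc(-c2ccc(-c3ccc(-c4nc5ccccc5[nH]4)cc3)cc2)cc1`, is the reference. In a functional assay on Gurav cells (Homo sapiens) for inhibition, read by sulforhodamine B assay (a higher number here means a weaker inhibitor of growth, a lower number a stronger inhibitor of growth), compound 1 gives 100000 nM. Compound 2, `FC(F)(F)c1ccc(-c2ccc(-c3ccc(-c4nc5ccccc5[nH]4)cc3)cc2)cc1`, carries the change trifluoromethyl in place of fluoro on an aromatic carbon on the same core; in this assay compound 2 gives 39100 nM, and the step is a 2.6-fold lower number from compound 1 to compound 2 (0.41 log units; beyond the scatter). Compound 3, `Cc1ccc2[nH]c(-c3ccc(-c4ccc(-c5ccc(F)cc5)cc4)cc3)nc2c1`, differs from compound 1 at the core by methyl in place of hydrogen on an aromatic carbon; in this assay compound 3 gives 16500 nM, the lowest of the three measured numbers, and the step is a 6.1-fold lower number from compound 1 to compound 3 (0.78 log units; beyond the scatter). Compound 2 and compound 3 stand apart by more than the usual scatter, with compound 3 the lower.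

Compound 4, `Cc1ccc2[nH]c(-c3ccc(-c4ccc(-c5ccc(C(F)(F)F)cc5)cc4)cc3)nc2c1`, is not yet measured. Among the measured compounds shown here, it stands to compound 3 as compound 2 stands to compound 1: the change trifluoromethyl in place of fluoro on an aromatic carbon is the same change as the one from compound 1 to compound 2, made at the same place. On the core of compound 1 that change gave a 2.6-fold lower number from compound 1 to compound 2 (0.41 log units; beyond the scatter). For the measured compounds named here, only one such pair is known, so the transfer of the step onto the methyl-bearing core of compound 3 is an assumption, not a pattern.

The step from compound 3 to compound 4 in this assay is expected to be about a 2.5-fold lower number from compound 3 to compound 4 (0.40 log units; beyond the scatter), resting on compound 1 to compound 2 giving a 2.6-fold lower number from compound 1 to compound 2 (0.41 log units; beyond the scatter). In this assay compound 4 is therefore estimated at 6500 nM, with a likely range from 3000 nM to 14000 nM.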

Compound 4, concentration for 50% growth inhibition: 12000 nM
Estimate against measurement, compound 4: 1.8-fold (0.27 log units) below, within the range that was stated.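

In this assay, trifluoromethyl in place of fluoro on the methyl-bearing core gives a 1.4-fold lower number from compound 3 to compound 4 (0.14 log units; within the scatter), a step that does not clear the scatter, yet it cannot be told apart from the same change on the core of compound 1: the same change on two cores in this assay, a 2.6-fold lower number (0.41 log units; beyond the scatter) from compound 1 to compound 2 and a 1.4-fold lower number (0.14 log units; within the scatter) from compound 3 to compound 4, 1.9-fold (0.27 log units) apart, within the scatter of two such steps
Methyl in place of hydrogen, read with trifluoromethyl in place of fluoro, gives a 3.3-fold lower number from compound 2 to compound 4 (0.51 log units; beyond the scatter), a step beyond the scatter and in the same direction as on the fluoro-bearing pair, and again the two readings cannot be told apart: the same change on two cores in this assay, a 6.1-fold lower number (0.78 log units; beyond the scatter) from compound 1 to compound 3 and a 3.3-fold lower number (0.51 log units; beyond the scatter) from compound 2 to compound 4, 1.9-fold (0.27 log units) apart, within the scatter of two such steps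
Across these four compounds, each change therefore carries from one core to the other with no measurable dependence on the other group, but with only two readings of each change, this does not show that the steps add up in general or that a small dependence is absent.

The compounds shown leave open how an amine, a carboxylic acid or a methoxy group would read in this assay in place of fluoro or trifluoromethyl. They also leave open whether a longer chain in place of the methyl on the core would keep to the same steps.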